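The source may report more compounds than this note shows. Statements on the series, on what has been measured and on what is new or still open speak of the compounds shown alone.

Compound 2 `CCn1c(C(=O)NCCN)ccc1C(CC)(CC)c1ccc(OCC(O)C(C)(C)C)c(C)c1` gives 10 nM in an assay on HL-60 cells for agonist activity at vitamin D3 receptor (Homo sapiens), read by microscopy, with a stated time of 96 h (on this read-out lower numbers stand for an effect already at smaller amounts and higher numbers for an effect only at larger amounts of compound), the lowest of the two numbers measured. Compound 1 `C#CC(C)OC(=O)c1ccc(C(CC)(CC)c2ccc(OCC(=O)C(C)(C)C)c(C)c2)n1CC`, which carries a different side chain and a different group on the carbonyl carbon, gives 210 nM. Compound 3 `C#CC(C)OC(=O)c1ccc(C(CC)(CC)c2ccc(OCC(O)C(C)(C)C)c(C)c2)n1CC` has not yet been measured. It differs from compound 2 in one place: (1-methylprop-2-yn-1-yl)oxy in place of (2-aminoethyl)amino on a carbonyl carbon. Within the data shown here, no single-change step between measured compounds is available, so the expectation rests on the two values alone. The step of a 6.0-fold higher number from compound 2 to compound 3 (0.78 log units; beyond the scatter) is expected to raise the number beyond the scatter, toward where compound 1 stands. For compound 3 the estimate in this assay is 60 nM, within 15 nM to 250 nM.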

Compound 3, half-maximal effective concentration: 200 nM
Beside the measured number, compound 3's estimate is 3.3-fold (0.52 log units) below it, and the stated range covers the measured number.
By their numbers in this assay, from the lowest: compound 2; then compounds 3 and 1 (each within the scatter of the next).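

In this assay, (1-methylprop-2-yn-1-yl)oxy in place of (2-aminoethyl)amino on the carbonyl carbon gives a 20-fold higher number from compound 2 to compound 3 (1.30 log units; beyond the scatter) with the rest of the molecule unchanged, so the group at this position alone can shift the number greatly. With (1-methylprop-2-yn-1-yl)oxy present, 1-hydroxy-2,2-dimethylpropyl in place of (tert-butyl)carbonyl gives a 1.1-fold lower number from compound 1 to compound 3 (0.02 log units; within the scatter) and so leaves the number within the scatter. Nothing measured here explains the large step. Still open, from the compounds shown here alone, is whether a simple ethylamino group or a carboxylic acid on this carbonyl carbon would keep the lower number, and whether (tert-butyl)carbonyl would matter alongside (2-aminoethyl)amino.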